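The compounds below may be only part of what the source reports. "The series", "measured", "known", "first", "only" and "open" are said of these compounds alone.

Measured so far in a physicochemical assay for lipophilicity; a lower number here means a more polar compound, a higher number a more lipophilic compound
- compound 1 `C[C@H]1CC[C@@H]2[C@@H](OC(=O)[C@]23CC(c2ccc(Cl)cc2)N(c2ccccc2)O3)[C@]2(C)C(=O)C=C[C@@]12O` gives 3.87
- compound 2 `C[C@H]1CC[C@@H]2[C@@H](OC(=O)[C@]23CC(c2cccc(F)c2)N(c2ccccc2)O3)[C@]2(C)C(=O)C=C[C@@]12O` gives 3.35

Of these two numbers, compound 2 holds the lower, and compound 1 stands beyond the scatter above it. Next is compound 3 `C[C@H]1CC[C@@H]2[C@@H](OC(=O)[C@]23CC(c2c(F)c(F)c(F)c(F)c2F)N(c2ccccc2)O3)[C@]2(C)C(=O)C=C[C@@]12O`, with 2,3,4,5,6-pentafluorophenyl in place of 3-fluorophenyl on a saturated ring carbon and the rest of compound 2 unchanged. For the measured compounds named here, one measured step bears on this, a number 0.52 log units lower from compound 1 to compound 2 (beyond the scatter) at the same ring carbon, so this assay has moved with a change of this aryl group. Going by the values given here, that step offers a guide to size only, since no measured compound carries a pentafluorophenyl group. A step of similar size, upward, is expected. The expected move is a number 0.50 log units higher from compound 2 to compound 3 (beyond the scatter) in this estimate. Compound 3 is estimated at 3.85 with an expected range of 3.4 to 4.35 for the measurement.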

Compound 3, partition coefficient: 3.72
Beside the measured number, compound 3's estimate is 0.13 log units above it; the range from low to high includes it.
By their numbers in this assay, from the lowest: compound 2; then compounds 3 and 1 (each within the scatter of the next).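

In this assay, the aryl group on the saturated ring carbon next to the ring nitrogen now moves the read-out upward as well as downward: 2,3,4,5,6-pentafluorophenyl in place of 3-fluorophenyl gives a number 0.37 log units higher from compound 2 to compound 3 (beyond the scatter) on the shared core. Set against 4-chlorophenyl, the same group gives a number 0.15 log units lower from compound 1 to compound 3 (within the scatter) and so cannot be told apart from it here, which leaves 3-fluorophenyl as the one aryl group of the three that stands apart from both others. Nothing available explains either step.

On these data alone, all three aryl groups at this carbon carry halogen, so the place of an unsubstituted phenyl, a pyridyl ring or a phenyl bearing an amine or a carboxylic acid on this scale remains open. Compound 1 and compound 2 differ in both halogen and its ring position, so 4-fluorophenyl or 3-chlorophenyl would be needed to separate the two in this assay here.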